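This account rests on a few compounds, and the source may have more. Where it says the series, first, only, none or still open, it means among the compounds named here.

Compound 1, `CC(C)CCn1c(OC2CCN(C(=O)c3ccco3)CC2)nc2ccccc21`, in an assay on isolated protein for inhibition of aldehyde dehydrogenase 1A1 (Homo sapiens), read by spectrophotometry, tested at 10 uM; a lower number here means less inhibition, a higher number more inhibition at the concentration tested (going by the name of the read-out): compound 1 gives 30.8%.
Compound 2, `Cc1cccc(Cn2c(CN3CCN(C(=O)c4ccc(Br)cc4)CC3)nc3ccccc32)c1`: compound 2 gives 25.8%.
Compound 3, `Cc1ccc(Cn2c(CN3CCN(C(=O)C4CC4)CC3)nc3ccccc32)cc1`: compound 3 gives 51.5%.

Among these three numbers compound 2 stands lowest. Compound 1 lies nearest to it, a number higher by an amount within the usual scatter, so the two cannot be put in order. Compound 3 stands furthest from compound 2, and that gap lies beyond the scatter.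

Compound 4, `CC(=O)N1CCN(Cc2nc3ccccc3n2Cc2cccc(C)c2)CC1`, has not yet been measured. It differs from compound 2 in one place: methyl in place of 4-bromophenyl on a carbonyl carbon. Going by the values given here, no step between two measured compounds that share this change is available, so the expectation rests on the spread of the three numbers alone. Compound 4 is expected to stay in the lower part of that spread, with a step of a number 9.2 percentage points higher from compound 2 to compound 4 (within the scatter) that is expected to be small, upward, and not clearly beyond the scatter. Compound 4 is estimated at 35%, likely between 15% and 55%.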

Compound 4, a percentage reported as inhibition, at one concentration (the size of the read-out at that concentration, not a potency): 70.3%
Compound 4: the middle estimate sits 35.3 percentage points below what was measured; measured number outside the range, above it.
By their numbers in this assay, from the lowest: compounds 2 and 1 (each within the scatter of the next); then compound 3; then compound 4.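

In this assay the step of a number 44.5 percentage points higher from compound 2 to compound 4 (beyond the scatter) shows that this position is not indifferent to what the carbonyl carries: with the rest of compound 2 unchanged, methyl in place of 4-bromophenyl on a carbonyl carbon moves the read-out beyond the scatter. Going by these compounds alone, this is the only step here between two compounds that differ in one place, and inhibition at the tested concentration rises as the ring and the bromine leave. Nothing measured here explains the size of this step.

As far as these compounds go, it remains open whether the ring or the bromine matters, as a plain phenyl on the carbonyl would separate the two. Also open, from the compounds shown here alone, is how ethyl or a longer chain would compare with methyl, and whether the step would recur on a different core.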